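The source may report more compounds than this note shows. Statements on the series, on what has been measured and on what is new or still open speak of the compounds shown alone.

Compound 1 `N#Cc1ccc(F)cc1Cn1c(N2CCC[C@@H](N)C2)nc2c(-c3ccc(F)cc3)c[nH]c2c1=O`: 1.21 h
Compound 2 `N#Cc1ccc(F)cc1Cn1c(N2CCC[C@@H](N)C2)nc2c(-c3ccc(S(N)(=O)=O)cc3)c[nH]c2c1=O`: > 3.33 h

In an ADME assay on microsomes from liver (Rattus norvegicus) for metabolic stability, read by LC-MS, tested at 1 mM (on this read-out higher numbers stand for a longer-lived compound and lower numbers for a shorter-lived compound), compound 1 gives 1.21 h. Compound 2 reaches the assay limit, > 3.33 h, so its half-life is known only as a limit and not as a number. The step of an at least 2.7-fold higher number from compound 1 to compound 2 (0.43 log units; beyond the scatter) is accordingly a lower bound, as the limit of > 3.33 h in this assay, at which 1 of the 2 values shown sits, shows. Compound 3 `CS(=O)(=O)c1cccc(-c2c[nH]c3c(=O)n(Cc4cc(F)ccc4C#N)c(N4CCC[C@@H](N)C4)nc23)c1` carries 3-(methylsulfonyl)phenyl in place of 4-sulfamoylphenyl on an aromatic carbon. Among the compounds with values here, no measured step covers this change, so the expectation rests on compound 2 sitting at the limit. Compound 3 is expected to give 3 h, between 1.2 h and 6 h. That expectation amounts to an at least 1.1-fold lower number from compound 2 to compound 3 (0.04 log units; that floor lies within the scatter), with the limit likely reached again.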

Compound 3, half-life: 1.65 h
Estimate against measurement, compound 3: 1.8-fold (0.26 log units) above; the measured number falls inside the stated range.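

In this assay, the exchange of 4-sulfamoylphenyl for 3-(methylsulfonyl)phenyl gives an at least 2.0-fold lower number from compound 2 to compound 3 (0.30 log units; that floor lies within the scatter), a size that is only a floor, as the value of compound 2 is a limit. Against 4-fluorophenyl at the same position, the exchange gives a 1.4-fold higher number from compound 1 to compound 3 (0.13 log units; within the scatter). A sulfonyl group on this phenyl ring therefore does not by itself set compound 3 apart from compound 1.

The exchange alters the group and its place on the ring together, and the two remain unseparated. On these data alone, how a carboxylic acid or a primary amine on this phenyl ring would behave stays open.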